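A few compounds are considered here, and "the series" means these few. Any claim that something is new, unique, unknown or untested is made for them only; others in the source may bear on it.

Measured so far in an assay on isolated protein with Bile acid receptor (Homo sapiens) as the target; on this read-out lower numbers stand for an effect already at smaller amounts and higher numbers for an effect only at larger amounts of compound:
compound 1 `COC(=O)/C=C/c1cccc(N(Cc2ccc(/C=C/c3c(C)cc(C)cc3C)cc2)C(=O)C(C)C)c1`: 149 nM
compound 2 `COC(=O)/C=C/c1cccc(N(Cc2ccc(-c3ccc(C(C)(C)C)cc3)cc2)C(=O)C2CCCCC2)c1`: 132 nM
compound 3 `COC(=O)/C=C/c1cccc(N(Cc2ccc(/C=C/C(=O)NC(C)(C)C)cc2)C(=O)C2CCCCC2)c1`: > 1000 nM, which is a limit of this assay and not a number.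

Compound 1 gives the higher of the two numbers, but its nearest neighbour is compound 2, whose value lies within the scatter of that of compound 1. Compound 4 `COC(=O)/C=C/c1cccc(N(Cc2ccc(-c3cccc(OC)c3)cc2)C(=O)C(C)C)c1` differs from compound 1 by 3-methoxyphenyl in place of 2-(2,4,6-trimethylphenyl)ethenyl on an aromatic carbon. For the measured compounds named here, the only measured step, an at least 7.5-fold higher number from compound 2 to compound 3 (0.87 log units; beyond the scatter), swaps 4-(tert-butyl)phenyl for 2-((tert-butyl)carbamoyl)ethenyl and reaches the limit (the limit of > 1000 nM in this assay, at which 1 of the 3 values shown sits); it bears on compound 4 only loosely, since 3-methoxyphenyl keeps an aromatic ring at that position. Compounds 1 and 2 show that two different aryl-bearing groups there give values within the scatter of each other, so no step beyond the scatter is expected: a 1.1-fold higher number from compound 1 to compound 4 (0.03 log units; within the scatter). Compound 4 is estimated at 160 nM, between 60 nM and 450 nM.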

Compound 4, half-maximal effective concentration: 72 nM
Compound 4: middle estimate off by 2.2-fold (0.35 log units), on the high side; measured number inside the range.
By their numbers in this assay, from the lowest: compounds 4, 2 and 1 (each within the scatter of the next, the first and the last beyond it). At a limit, above all of these: compound 3.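

In this assay, for the compounds shown here, this position responds to a change that keeps an aromatic ring: replacing 2-(2,4,6-trimethylphenyl)ethenyl with 3-methoxyphenyl gives a 2.1-fold lower number from compound 1 to compound 4 (0.32 log units; beyond the scatter) as the first step here with a number at both ends. The entering group is the smaller one by heavy atoms, with one hydrogen-bond acceptor and no double bond outside the ring, so a larger group is not required here. No measured property shown bears on this step.

From the compounds shown here alone, whether the methoxy oxygen or the loss of the ethenyl link carries the step stays open. An unsubstituted phenyl at this place would separate the two.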